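The compounds below may be only part of what the source reports. "The series", "measured", "known", "first", "only" and "open" are said of these compounds alone.

Measured so far:
compound 1, `CCC(C(=O)N1CCN(c2cccc(F)c2)CC1)N1C(=O)CCC1=O`, 0%
compound 2, `CC(C(=O)N1CCN(c2ccccc2F)CC1)N1C(=O)CCC1=O`, 75%

Of the compounds shown here, two have been tested in a functional assay on the whole organism (strain Swiss) with Mus musculus as the target, in the maximal electroshock model, with a stated time of 0.25 h, at a dose of 100 mg/kg by the intraperitoneal route; on this read-out lower numbers stand for a weaker effect and higher numbers for a stronger effect at the one dose given. Compound 1, with the structure `CCC(C(=O)N1CCN(c2cccc(F)c2)CC1)N1C(=O)CCC1=O`, gives 0%. Compound 2, with the structure `CC(C(=O)N1CCN(c2ccccc2F)CC1)N1C(=O)CCC1=O`, gives 75%. Compound 2 therefore stands highest of the two numbers, and the gap to compound 1 lies well beyond the usual scatter of this kind of measurement. Compound 1 and compound 2 differ in more than one place, so the two values alone do not tell which part of the structure carries the difference.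

The step now followed leads to compound 3, with the structure `CCC(C(=O)N1CCN(c2ccccc2F)CC1)N1C(=O)CCC1=O`, which is not yet measured. It differs from compound 2 in one place: methyl in place of hydrogen on a saturated chain carbon, two bonds along the chain from an amide-type nitrogen in a ring and a carbonyl carbon. Going by the values given here, compound 1 carries this same chain and shows no effect in this assay, though its fluorine sits elsewhere, so no counted step settles the question. The expectation is a step downward, a number 35 percentage points lower from compound 2 to compound 3 (beyond the scatter), with wide uncertainty. For compound 3 the estimated value in this assay is 40%, expected to fall between 0% and 85%.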

Compound 3, a percentage reported as activity, at one dose (the size of the read-out at that dose, not a potency): 0%
The estimate for compound 3 lay 40 percentage points above the measured number, and the stated range covers the measured number.
By their numbers in this assay, from the lowest: compounds 1 and 3 (each within the scatter of the next); then compound 2.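

In this assay, going by these compounds alone, the step from a hydrogen to a methyl on the saturated chain carbon, two bonds along the chain from an amide-type nitrogen in a ring and a carbonyl carbon, gives a number 75 percentage points lower from compound 2 to compound 3 (beyond the scatter), and this is the first reading of this one change on its own. With the methyl in place, 2-fluorophenyl in place of 3-fluorophenyl on an amine nitrogen in a ring gives no change at the digits printed from compound 1 to compound 3 (within the scatter), so this change of fluorophenyl group shows no effect on this read-out, although with compound 3 at 0% and compound 1 at 0%, any difference that lies under a zero at this single dose stays hidden. Nothing among the data shown gives a reason for the loss of effect that comes with the methyl.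

Whether the same methyl step holds with 3-fluorophenyl on the amine nitrogen stays open, as no compound shown pairs that group with a hydrogen at this chain carbon. From the compounds shown here alone, how a longer chain such as propyl at this carbon, or a phenyl group without fluorine on the amine nitrogen, would read in this assay also stays open.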